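A Chalcone Arm in Place of Acetyl: Expected Cytotoxicity

The source may report more compounds than this note shows. Statements on the series, on what has been measured and on what is new or still open speak of the compounds shown alone.

Compound 1 `O=C(CSC(=S)N[C@H]1CCOC1=O)Nc1ccc(F)cc1` in a functional assay on SMMC-7721 cells (Homo sapiens) for cytotoxicity, read by MTT assay, with a stated time of 72 h (a lower number here means a stronger inhibitor, a higher number a weaker inhibitor), sits at the limit > 128000 nM.
Compound 2 `CC(=O)c1ccc(NC(=O)CSC(=S)N[C@H]2CCOC2=O)cc1` in this assay sits at the limit > 128000 nM.
Compound 3 `CCCCc1ccc(NC(=O)CSC(=S)N[C@H]2CCOC2=O)cc1` in this assay gives 27300 nM.

The three measured compounds share one core and differ only in the group on the aromatic ring of the amide. Compound 2 stands at the limit of this assay, so its value is not a number; it shares this with compound 1, as the limit of > 128000 nM in this assay, at which 2 of the 3 values shown sit, shows. Only compound 3 gives a readable number. The step of an at least 4.6-fold lower number from compound 2 to compound 3 (0.67 log units; beyond the scatter) and the step of an at least 4.6-fold lower number from compound 1 to compound 3 (0.67 log units; beyond the scatter) both lead to that number, while the step that the two limits leave unreadable from compound 1 to compound 2 runs between two limits and cannot be read.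

Compound 4 `O=C(CSC(=S)N[C@H]1CCOC1=O)Nc1ccc(C(=O)/C=C/c2ccccc2Cl)cc1` is built from compound 2 by the change (2-(2-chlorophenyl)ethenyl in place of methyl on a carbonyl carbon), the new group entering on a carbonyl carbon whose other neighbour is an aromatic carbon. Going by the values given here, the only readable steps, from compound 2 to compound 3 and from compound 1 to compound 3, each bring a larger carbon group onto the ring and each give a lower number in this assay. Compound 4 is therefore expected to move off the limit, with the estimated step of an at least 5.1-fold lower number from compound 2 to compound 4 (0.70 log units; beyond the scatter). For compound 4 the expected value in this assay is 25000 nM, estimated between 5000 nM and 128000 nM.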

Compound 4, half-maximal inhibitory concentration: 20400 nM
Beside the measured number, compound 4's estimate is 1.2-fold (0.09 log units) above it; the range from low to high includes it.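

The earlier readable steps replaced the whole group on the aromatic ring with butyl, so they showed nothing about the carbonyl carbon of compound 2. Here the carbonyl stays in place and only the methyl on it gives way to 2-(2-chlorophenyl)ethenyl, and the result in this assay is an at least 6.2-fold lower number from compound 2 to compound 4 (0.79 log units; beyond the scatter). On these data alone, a readable number can therefore also be reached with the carbonyl kept, by building out from this carbonyl carbon, though the true size of the step stays unknown, since compound 2 gives only a limit and not a number: the limit of > 128000 nM in this assay, at which 2 of the 4 values shown sit.

The new group brings an aromatic ring, a double bond and a chlorine in one single change, so the compounds shown do not tell which of these parts carries the step. As far as these compounds go, whether a plain phenyl ring without the chlorine, a saturated chain in place of the double bond, or an amine or a carboxylic acid on this same carbonyl carbon would give a lower or a higher number remains open.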